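The source may report more compounds than this note shows. Statements on the series, on what has been measured and on what is new or still open speak of the compounds shown alone.

Compound 1 `CCc1ccccc1NC(=O)N[C@@H](C)c1ccccc1`: 100%
Compound 2 `C[C@H](NC(=O)Nc1ccccc1C(C)(C)C)c1ccccc1`: 99%
Compound 3 `C[C@H](NC(=O)Nc1ccccc1C(F)(F)F)c1ccccc1`: 98%

These three compounds share one core and differ only in the group on an aromatic carbon. In an ADME assay on the whole organism with Oryza sativa as the target, tested at 1 uM (on this read-out higher numbers stand for a weaker effect at the one concentration tested and lower numbers for a stronger effect), compound 1 gives 100%, compound 2 gives 99% and compound 3 gives 98%. On paper compound 3 carries the lowest of the three numbers, yet its gaps to compound 2 and to compound 1 both lie within the scatter, so the three cannot be told apart. The measured steps were a number 1 percentage points lower from compound 1 to compound 2 (within the scatter), a number 2 percentage points lower from compound 1 to compound 3 (within the scatter) and a number 1 percentage points lower from compound 2 to compound 3 (within the scatter).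

Compound 4 `COc1ccccc1NC(=O)N[C@@H](C)c1ccccc1` differs from compound 3 in one place: methoxy in place of trifluoromethyl on an aromatic carbon. All three earlier steps swapped one group on this same aromatic carbon, and none of them moved the read-out beyond the scatter, so no step beyond the scatter is expected in this assay here either; the expected step is no change at the digits printed from compound 3 to compound 4 (within the scatter). Compound 4 is therefore estimated at 98%, between 90% and 100%.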

Compound 4, a percentage reported as activity, at one concentration (the size of the read-out at that concentration, not a potency): 99%
Compound 4: the middle estimate sits 1 percentage points below what was measured; the range from low to high includes it.
By their numbers in this assay, from the lowest: compounds 3, 2, 4 and 1 (each within the scatter of the next).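

Methoxy is the first group on this aromatic carbon to bring an oxygen and a hydrogen-bond acceptor, yet in this assay the steps are a number 1 percentage points higher from compound 3 to compound 4 (within the scatter), no change at the digits printed from compound 2 to compound 4 (within the scatter) and a number 1 percentage points lower from compound 1 to compound 4 (within the scatter). So on this carbon, ortho to a large group, even a swap that changes the atoms and leaves fewer heavy atoms gives a compound that cannot be told apart from the other three at the one concentration tested. No measurement available here bears on this result.

On these data alone, whether an amine or a carboxylic acid on this same carbon would give a step beyond the scatter stays open. So does whether any group placed elsewhere on the six-membered aromatic ring, or a change to the rest of the shared core, would do so.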